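The compounds below may be only part of what the source reports. "The series", "measured", "known", "first", "only" and "open" are said of these compounds alone.

In a functional assay on MCF7 cells (Homo sapiens) for inhibition, read by sulforhodamine B assay, with a stated time of 48 h (a higher number here means a weaker inhibitor of growth, a lower number a stronger inhibitor of growth), compound 1, `CC1(/C=C/c2ccccc2)C=CC(=O)O1`, gives 95300 nM, compound 2, `COc1ccc(/C=C/C2(C)C=CC(=O)O2)cc1OC`, gives 78900 nM, and compound 3, `CC1(/C=C/c2cccc(O)c2)C=CC(=O)O1`, gives 124000 nM. These three values lie within the scatter of one another, so compound 3 stands apart from neither of the others. Compound 4, `COc1cccc(/C=C/C2(C)C=CC(=O)O2)c1`, differs from compound 3 by methyl in place of hydrogen on an oxygen on an aromatic ring, hydroxy to methoxy. For the measured compounds named here, the one measured step that bears on this is a 1.3-fold higher number from compound 1 to compound 3 (0.11 log units; within the scatter), which lies within the scatter. Compound 2, which also bears methoxy, gives 78900 nM. No change beyond the scatter is therefore expected in this assay, and the estimated step is a 1.3-fold lower number from compound 3 to compound 4 (0.13 log units; within the scatter). The expected value for compound 4 is 92000 nM, with an estimated range from 55000 nM to 150000 nM.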

Compound 4, concentration for total growth inhibition: 25300 nM
Estimate against measurement, compound 4: 3.6-fold (0.56 log units) above; the measured number lies below the stated range.
By their numbers in this assay, from the lowest: compound 4; then compounds 2, 1 and 3 (each within the scatter of the next).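

In this assay, methyl on the oxygen of the aromatic hydroxy group changes the result beyond the scatter (a 4.9-fold lower number from compound 3 to compound 4 (0.69 log units; beyond the scatter)), whereas the earlier hydroxy in place of hydrogen stayed within it (a 1.3-fold higher number from compound 1 to compound 3 (0.11 log units; within the scatter)). A lone methoxy group also separates from the unsubstituted compound (a 3.8-fold lower number from compound 1 to compound 4 (0.58 log units; beyond the scatter)), and hydrogen in place of the other methoxy group in compound 2 gives a further step (a 3.1-fold lower number from compound 2 to compound 4 (0.49 log units; beyond the scatter)), so the extra methoxy group does not share this lower number. No evidence explains these steps. From the compounds shown here alone, whether ethoxy or an amine at this place would hold the lower number remains open.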